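The compounds below may be only part of what the source reports. "The series", "measured", "known", "first", "only" and "open" are said of these compounds alone.

Measured compounds:
Compound 1, `COc1cc(NC(=O)Nc2cc(Nc3ccc(C)c(F)c3)ncn2)cc(OC)c1` — in a functional assay on NCI-H1581 cells (Homo sapiens) for inhibition, read by MTT assay, with a stated time of 48 h, tested at 10 uM (on this read-out higher numbers stand for more inhibition at the one concentration tested (going by the name of the read-out) and lower numbers for less inhibition), compound 1 gives 38%.
Compound 2, `CCc1cccc(Nc2cc(NC(=O)Nc3cc(OC)cc(OC)c3)ncn2)c1` — in this assay compound 2 gives 27.7%.

Of the two numbers shown, compound 2 stands lowest; its nearest neighbour is compound 1, and the step of a number 10.3 percentage points lower from compound 1 to compound 2 (beyond the scatter) separates them, a gap beyond the scatter. Compound 3, `COc1cc(NC(=O)Nc2cc(Nc3cc(C)cc(F)c3)ncn2)cc(OC)c1`, has not yet been measured in this assay. It differs from compound 2 in one place: 3-fluoro-5-methylphenyl in place of 3-ethylphenyl on a nitrogen on an aromatic ring.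

Among the compounds with values here, the one measured step that bears on this change is a number 10.3 percentage points lower from compound 1 to compound 2 (beyond the scatter), in which the 3-ethylphenyl group came in for a phenyl carrying a fluorine and a methyl group, and the number fell modestly. Compound 3 reverses that exchange in spirit, bringing a fluorine and a methyl group back onto the phenyl, though as 3-fluoro-5-methylphenyl rather than 3-fluoro-4-methylphenyl. Whether the two arrangements behave alike is not shown by any measured pair here, so the expectation leans on that single step alone. Compound 3 is therefore expected to sit somewhat higher than compound 2, by the estimated step of a number 6.3 percentage points higher from compound 2 to compound 3 (within the scatter), which may or may not clear the scatter. The estimated value for compound 3 in this assay is 34%, with a range from 22% to 47%.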

Compound 3, a percentage reported as inhibition, at one concentration (the size of the read-out at that concentration, not a potency): 28.3%
Compound 3: the middle estimate sits 5.7 percentage points above what was measured, within the range that was stated.
By their numbers in this assay, from the lowest: compounds 2, 3 and 1 (each within the scatter of the next, the first and the last beyond it).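

In this assay, 3-fluoro-5-methylphenyl in place of 3-ethylphenyl on a nitrogen on an aromatic ring gives a number 0.6 percentage points higher from compound 2 to compound 3 (within the scatter), so at this position the fluorine and methyl pair does not by itself set a compound apart from the 3-ethylphenyl compound 2. The exchange of 3-fluoro-4-methylphenyl for 3-fluoro-5-methylphenyl gives a number 9.7 percentage points lower from compound 1 to compound 3 (within the scatter), which is also within the scatter, so compound 3 cannot be told apart from either neighbour, even though a number 10.3 percentage points lower from compound 1 to compound 2 (beyond the scatter) separates the other two compounds and the arrangement of the fluorine and methyl groups is not shown to matter. No measurement available here speaks to what lies behind these numbers.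

All three groups at this position are substituted phenyl rings, so the compounds shown leave open how the read-out would respond to a phenyl ring carrying an amine or a carboxylic acid, or to a longer alkyl chain in place of the ethyl group. With the rest of the molecule held constant and a single concentration behind each number, they also leave open how these compounds differ in potency.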